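Replacing 4-methoxyphenyl with naphthalen-1-yl on a sulfonyl sulfur

A few compounds are considered here, and "the series" means these few. Any claim that something is new, unique, unknown or untested is made for them only; others in the source may bear on it.

Compound 1 `COc1cc(-c2nc(-c3ccccc3)[nH]c2-c2ccnc(NCCCNS(=O)(=O)c3ccc(Br)cc3)n2)ccc1F` gives 33900 nM
Compound 2 `COc1ccc(S(=O)(=O)NCCCNc2nccc(-c3[nH]c(-c4ccccc4)nc3-c3ccc(F)c(OC)c3)n2)cc1` gives 6130 nM

In a functional assay on LOX IMVI cells (Homo sapiens) for cytotoxicity, read by MTT assay, with a stated time of 24 h (a lower number here means a stronger inhibitor, a higher number a weaker inhibitor), compound 2, at 6130 nM, holds the lower of the two numbers and is the stronger inhibitor. Compound 3 `COc1cc(-c2nc(-c3ccccc3)[nH]c2-c2ccnc(NCCCNS(=O)(=O)c3cccc4ccccc34)n2)ccc1F` differs from it by naphthalen-1-yl in place of 4-methoxyphenyl on a sulfonyl sulfur. Going by the values given here, only one measured step bears on this, methoxy in place of bromo on an aromatic carbon, which is modest: a 5.5-fold lower number from compound 1 to compound 2 (0.74 log units; beyond the scatter). Losing the 4-methoxyphenyl group may therefore raise the number, by a similar or smaller size, though no measured compound carries naphthalen-1-yl. The estimate for compound 3 is 12000 nM, with an expected range of 3500 nM to 35000 nM. This means an expected 2.0-fold higher number from compound 2 to compound 3 (0.29 log units; within the scatter).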

Compound 3, half-maximal inhibitory concentration: 14900 nM
Compound 3: the middle estimate sits 1.2-fold (0.09 log units) below what was measured, within the range that was stated.
By their numbers in this assay, from the lowest: compound 2; then compound 3; then compound 1.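

In this assay, the larger naphthalen-1-yl group does not move the number in one direction: it gives a 2.4-fold higher number from compound 2 to compound 3 (0.39 log units; beyond the scatter) when it replaces 4-methoxyphenyl, but a 2.3-fold lower number from compound 1 to compound 3 (0.36 log units; beyond the scatter) when it replaces 4-bromophenyl. Adding a second aromatic ring therefore neither matches the best phenyl group nor falls to the level of the worst. Nothing available explains this order. Still open, going by these compounds, is whether a plain phenyl, a naphthalen-2-yl or a non-aromatic cyclohexyl on the sulfonyl sulfur would go lower than compound 2.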